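This account rests on a few compounds, and the source may have more. Where it says the series, first, only, none or still open, it means among the compounds named here.

Compound 1 `Cc1ccc(Cn2cc(COc3ccc4c(=O)ccoc4c3)nn2)cc1`: in a functional assay on HeLa cells (Homo sapiens) for cytotoxicity, read by MTT assay, with a stated time of 48 h (a lower number here means a stronger inhibitor, a higher number a weaker inhibitor), compound 1 gives > 100000 nM, a limit of the assay.
Compound 2 `O=c1ccoc2cc(OCc3cn(Cc4cccc([N+](=O)[O-])c4)nn3)ccc12`: in this assay compound 2 gives 17300 nM.
Compound 3 `O=c1ccoc2cc(OCc3cn(Cc4ccc(Br)cc4)nn3)ccc12`: in this assay compound 3 gives > 100000 nM, a limit of the assay.

Compound 3 thus stands at the limit of > 100000 nM in this assay, at which 2 of the 3 values shown sit, with no number of its own. Compound 4 `COc1ccc(Cn2cc(COc3ccc4c(=O)ccoc4c3)nn2)cc1` differs from it by methoxy in place of bromo on an aromatic carbon. For the measured compounds named here, no measured step brings in a methoxy. Going by the values given here, the steps that come nearest are a step that the two limits leave unreadable from compound 1 to compound 3, together with the two steps touching the single numbered value, an at least 5.7-fold lower number from compound 1 to compound 2 (0.76 log units; beyond the scatter) and an at least 5.7-fold higher number from compound 2 to compound 3 (0.76 log units; beyond the scatter). Only compound 2, carrying 3-nitrophenyl, has a number; compound 1 and compound 3, carrying 4-methylphenyl and 4-bromophenyl, both sit at the limit. For compound 4 the expected step is a number no higher from compound 3 to compound 4 (the limit leaves the size open), within the scatter. Compound 4 is therefore estimated to stay at the limit, at 100000 nM, between 30000 nM and 300000 nM.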

Compound 4, half-maximal inhibitory concentration: 14400 nM
Compound 4: the middle estimate sits 6.9-fold (0.84 log units) above what was measured, outside the stated range (below it).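

Changing only the group on the phenyl ring is enough to bring a number out of the limit in this assay: methoxy in place of bromo gives an at least 6.9-fold lower number from compound 3 to compound 4 (0.84 log units; beyond the scatter), and methoxy in place of methyl gives an at least 6.9-fold lower number from compound 1 to compound 4 (0.84 log units; beyond the scatter). Compound 2 no longer stands alone with a number: 4-methoxyphenyl in place of 3-nitrophenyl gives a 1.2-fold lower number from compound 2 to compound 4 (0.08 log units; within the scatter). Compound 1 and compound 3 still give no number of their own, only a limit: the limit of > 100000 nM in this assay, at which 2 of the 4 values shown sit.

The compounds shown leave open whether an amine, a hydroxy group or a fluoro at this same place would also give a number. They also leave open whether methoxy elsewhere on the phenyl ring would do the same.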